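This account rests on a few compounds, and the source may have more. Where it says the series, first, only, none or still open, it means among the compounds named here.

- compound 1 `CON(CCCCCCCCCCC#CCCCCc1cccnc1)[C@@H]1O[C@H](CO)[C@@H](O)[C@H](O)[C@H]1O` gives 11 ug/mL
- compound 2 `CON(CCCCCCCCC#CCCCCc1cccnc1)[C@@H]1O[C@H](CO)[C@@H](O)[C@H](O)[C@H]1O` gives 11 ug/mL

Going by the values given here, in a functional assay on P388 cells (Mus musculus) for cytotoxicity, read by MTT assay (on this read-out lower numbers stand for stronger inhibition and higher numbers for weaker inhibition), compound 1, at 11 ug/mL in the series so far, stands level with compound 2 at 11 ug/mL and apart from it by nothing beyond the scatter. Compound 3 `CON(CCCCCCCCCCC#CCCc1cccnc1)[C@@H]1O[C@H](CO)[C@@H](O)[C@H](O)[C@H]1O` carries pyridin-3-yl in place of 2-(pyridin-3-yl)ethyl on a saturated chain carbon, two bonds along the chain from a triple-bonded carbon. Among the compounds with values here, no measured step bears on this change, so in this assay no shift beyond the scatter is expected, in either direction. The expected step is (a 1.2-fold higher number from compound 1 to compound 3 (0.07 log units; within the scatter)). Compound 3 is estimated at 13 ug/mL (range 6 ug/mL to 30 ug/mL).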

Compound 3, half-maximal inhibitory concentration: 5 ug/mL
Compound 3: middle estimate off by 2.6-fold (0.41 log units), on the high side, outside the stated range (below it).
By their numbers in this assay, from the lowest: compound 3; then compounds 1 and 2 (each within the scatter of the next).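

Going by these compounds alone, measured in this assay the change from 2-(pyridin-3-yl)ethyl to pyridin-3-yl on a saturated chain carbon, two bonds along the chain from a triple-bonded carbon, gives a 2.2-fold lower number from compound 1 to compound 3 (0.34 log units; beyond the scatter) and so is the first step that lies beyond the scatter. It shows that this position responds to a change in the group it carries, although the response is modest and rests on a single pair of compounds. Nothing measured here accounts for the step. From the compounds shown here alone, whether a phenyl group in place of pyridin-3-yl would keep the lower number remains open. So does the effect of an amine at this position.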